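A few compounds are considered here, and "the series" means these few. Any claim that something is new, unique, unknown or untested is made for them only; others in the source may bear on it.

Measured compounds:
Compound 1 `COc1cc(OC)cc(C(=O)NC2CCN(CC[C@H](O)c3ccccc3)CC2)c1`: in an assay on isolated protein for binding affinity to melanin-concentrating hormone receptor 1 (Homo sapiens) (a lower number here means a stronger inhibitor, a higher number a weaker inhibitor), compound 1 gives 505 nM.
Compound 2 `COc1cc(OC)cc(C(=O)N[C@@H]2CCN(C(C)c3ccc4ccccc4c3)C2)c1`: in this assay compound 2 gives 12 nM.

Compound 2 holds the lower of the two numbers in this assay, and its gap to compound 1 lies beyond the scatter of the assay. The two compounds differ in more than one place, so no single change between them is recorded; only their two values stand.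

Compound 3 `COc1cc(OC)cc(C(=O)N[C@@H]2CCN(C(C)/C=C/c3ccccc3)C2)c1` is not yet measured. It differs from compound 2 in one place: 2-phenylethenyl in place of naphthalen-2-yl on a saturated chain carbon bound to an amine nitrogen in a ring and a saturated chain carbon. Among the compounds with values here, no measured pair shows this change, so there is no step to lean on. The naphthalen-2-yl group of compound 2 goes out and a 2-phenylethenyl group comes in, with one double bond outside aromatic rings; the remainder of the molecule is unchanged. A modest weakening is expected, within or a little beyond the scatter, rather than a large move away from compound 2. The step expected from compound 2 to compound 3 in this assay is a 3.3-fold higher number from compound 2 to compound 3 (0.52 log units; beyond the scatter). For compound 3 in this assay the estimate is 40 nM, with a range from 10 nM to 160 nM.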

Compound 3, inhibition constant: 23 nM
Compound 3: middle estimate off by 1.7-fold (0.24 log units), on the high side; measured number inside the range.
By their numbers in this assay, from the lowest: compounds 2 and 3 (each within the scatter of the next); then compound 1.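

In this assay, 2-phenylethenyl in place of naphthalen-2-yl, on a saturated chain carbon bound to an amine nitrogen in a ring and a saturated chain carbon, gives a 1.9-fold higher number from compound 2 to compound 3 (0.28 log units; within the scatter) and so leaves the two compounds indistinguishable. Within the data shown here, this is the first single-place change, and it shows that this position accepts one six-membered aromatic ring of carbon only, carried on a double bond outside aromatic rings, as well as it accepts the two such rings of naphthalen-2-yl, at least for this pair. No independent measurement bears on why the two groups read alike.

The compounds shown leave open whether the double bond matters at all: a saturated 2-phenylethyl group or a plain phenyl group at the same place would address that. Also open, going by these compounds, is how much change the position allows beyond carbon-only aromatic groups, for instance whether a pyridinyl ring or a longer chain ending in phenyl would read the same in this assay.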